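This account rests on a few compounds, and the source may have more. Where it says the series, first, only, none or still open, it means among the compounds named here.

Measured compounds:

Compound 1, `CCOc1cc(=O)n(CCCO)c2c1CC(CC=C(C)C)C(C)(C)C2`: 66.5%
Compound 2, `CC(C)=CCC1Cc2c(OCCCNS(=O)(=O)c3ccc(Cl)cc3)cc(=O)n(CCCO)c2CC1(C)C`: 24.7%
Compound 3, `CC(C)=CCC1Cc2c(OCCCNS(=O)(=O)c3ccc([N+](=O)[O-])cc3)cc(=O)n(CCCO)c2CC1(C)C`: 47.7%

In a functional assay on PANC-1 cells (Homo sapiens) for inhibition, read by MTT assay, with a stated time of 24 h, tested at 10 uM (a lower number here means less inhibition, a higher number more inhibition at the concentration tested (going by the name of the read-out)), compound 1 stands highest of the three measured numbers. Compound 3 comes nearest to it, and compound 2 lies furthest away. The two measured steps both concern what hangs from the oxygen on the aromatic ring of the shared core. Enlarging that side chain with a sulfonyl-bearing group gave a number 41.8 percentage points lower from compound 1 to compound 2 (beyond the scatter), a large loss of inhibition. Swapping one group on the appended ring for another gave a number 23 percentage points higher from compound 2 to compound 3 (beyond the scatter), a modest recovery, so the size of the loss depends on what the appended ring carries.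

Compound 4, `CC(C)=CCC1Cc2c(OC(=O)Nc3ccc(F)cc3)cc(=O)n(CCCO)c2CC1(C)C`, is not yet measured. It differs from compound 1 by (4-fluorophenyl)carbamoyl in place of ethyl on an oxygen on an aromatic ring. As in the first step, the small ethyl at this oxygen gives way to a much larger, ring-bearing group, so a drop in this assay beyond the scatter is expected, though the second step shows that such losses can be partly offset. Compound 4 is expected to reach about 40%, within 20% to 60%, which corresponds to an expected a number 26.5 percentage points lower from compound 1 to compound 4 (beyond the scatter).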

Compound 4, a percentage reported as inhibition, at one concentration (the size of the read-out at that concentration, not a potency): 71.2%
Beside the measured number, compound 4's estimate is 31.2 percentage points below it, and the stated range ends below it.
By their numbers in this assay, from the lowest: compound 2; then compound 3; then compounds 1 and 4 (each within the scatter of the next).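

In this assay, replacing ethyl on this oxygen with the much larger (4-fluorophenyl)carbamoyl gives a number 4.7 percentage points higher from compound 1 to compound 4 (within the scatter), so the two compounds cannot be told apart. Taken alone, the earlier step of a number 41.8 percentage points lower from compound 1 to compound 2 (beyond the scatter) might suggest that any large, ring-bearing group on this oxygen costs inhibition, but the new result shows that added size and an added aromatic ring do not by themselves bring such a loss: what matters is which group is attached, not merely that a big one is. No measured evidence is available that explains why the carbamoyl group and the sulfonyl-bearing chain behave differently here.

The compounds shown leave open whether the fluorine on the ring plays any part or the carbamoyl link alone accounts for the result, a question that a plain phenylcarbamoyl or a (4-chlorophenyl)carbamoyl group on the same oxygen would help to answer. Also open, on these data alone, is how a methyl group or a longer chain such as butyl on this oxygen would compare with ethyl.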